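This account rests on a few compounds, and the source may have more. Where it says the series, first, only, none or still open, it means among the compounds named here.

Of the compounds shown here, three from one series have been measured in a functional assay on HEK293 cells for agonist activity at D(4) dopamine receptor (Homo sapiens), read by FLIPR; on this read-out higher numbers stand for an effect only at larger amounts of compound and lower numbers for an effect already at smaller amounts. Compound 1 `O=C(NCN1CCC(c2cccc[n+]2[O-])CC1)c1ccccc1` gives 532 nM, compound 2 `Cc1cccc(NC(=O)CN2CCC(c3cccc(F)c3)CC2)c1` gives 512 nM, and compound 3 `CC(C)Oc1cccc(NC(=O)CN2CCC(c3cccc[n+]3[O-])CC2)c1` gives 555 nM. Compound 2 thus sits together with compound 1 and compound 3, with all three numbers within the usual scatter of one another, so none of them can be set apart from the others.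

Compound 4 `Cc1cccc(NC(=O)CN2CCC(c3ccccc3C)CC2)c1` is not yet measured. It differs from compound 2 by 2-methylphenyl in place of 3-fluorophenyl on a saturated ring carbon. Within the data shown here, no measured pair shows the effect of this particular exchange. Because compound 2 gives 512 nM and the three numbers in this assay hold together so closely, compound 4 is expected to land near that value, with a step of a 1.4-fold higher number from compound 2 to compound 4 (0.14 log units; within the scatter) that could well remain within the scatter. The estimate for compound 4 is 700 nM, with a range from 250 nM to 2500 nM.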

Compound 4, half-maximal effective concentration: 340 nM
The estimate for compound 4 lay 2.1-fold (0.31 log units) above the measured number; the measured number falls inside the stated range.
By their numbers in this assay, from the lowest: compounds 4, 2, 1 and 3 (each within the scatter of the next).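

The first pair differing in one place shows, in this assay, a 1.5-fold lower number from compound 2 to compound 4 (0.18 log units; within the scatter) with 2-methylphenyl in place of 3-fluorophenyl on the saturated ring carbon. At this position, therefore, the two substituted phenyl groups cannot be told apart, and this one exchange leaves the number within the scatter. Nothing at hand explains this result.

Still open, as far as these compounds go, is how this position responds to a phenyl ring carrying an amine or a carboxylic acid. From the compounds shown here alone, it is also open whether a longer chain in place of the ring would give a similar number.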